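A few compounds are considered here, and "the series" means these few. Any claim that something is new, unique, unknown or untested is made for them only; others in the source may bear on it.

Of the compounds shown here, three share one core and have been measured in a functional assay on U-87MG ATCC cells for antiproliferative activity against U-87 MG (Homo sapiens), read by MTT assay, with a stated time of 48 h, tested at 5 uM; a lower number here means a stronger effect, a higher number a weaker effect of the compound at the concentration tested. Compound 1 `COc1ccc(-c2nc(SCC(=O)c3sc(-c4ccccc4)nc3C)[nH]c(=O)c2C#N)cc1` gives 97.3%, compound 2 `Cc1nc(-c2ccc(Cl)cc2)sc1C(=O)CSc1nc(-c2cccc(Cl)c2)c(C#N)c(=O)[nH]1` gives 80.2%, and compound 3 `Cc1nc(-c2ccccc2)sc1C(=O)CSc1nc(-c2ccc(Cl)c(Cl)c2)c(C#N)c(=O)[nH]1` gives 98.6%. Compound 3 therefore holds the highest of the three numbers; compound 1 lies within the scatter of it, while compound 2 sits beyond the scatter at the lower end.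

Compound 4 `Cc1nc(-c2ccccc2)sc1C(=O)CSc1nc(-c2cccc(Cl)c2)c(C#N)c(=O)[nH]1` differs from compound 3 in one place: hydrogen in place of chloro on an aromatic carbon. For the measured compounds named here, the only measured step that touches the same aromatic ring is a number 1.3 percentage points higher from compound 1 to compound 3 (within the scatter), which shows that exchanging the group on this ring hardly moved the number. Going by the values given here, no measured pair isolates the loss of a single chloro. Compound 4 carries the same 3-chlorophenyl as compound 2, which differs elsewhere; the value of compound 2, 80.2%, is the lowest seen, so it leaves open that a 3-chlorophenyl may go with a somewhat lower number.

Weighing these, a small step is expected in this assay, a number 6.6 percentage points lower from compound 3 to compound 4 (within the scatter), probably within the scatter. Compound 4 is estimated at 92%, with a range from 76% to 103%.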

Compound 4, a percentage reported as activity, at one concentration (the size of the read-out at that concentration, not a potency): 86.9%
Estimate against measurement, compound 4: 5.1 percentage points above, within the range that was stated.
By their numbers in this assay, from the lowest: compounds 2 and 4 (each within the scatter of the next); then compounds 1 and 3 (each within the scatter of the next).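

Taking 3,4-dichlorophenyl to 3-chlorophenyl gives a number 11.7 percentage points lower from compound 3 to compound 4 (beyond the scatter) in this assay and so shows that this position on the ring can matter, since a lower number here means a stronger effect. The 3-chlorophenyl also stands apart from the 4-methoxyphenyl with a number 10.4 percentage points lower from compound 1 to compound 4 (beyond the scatter) as the result, although the earlier exchange of 4-methoxyphenyl for 3,4-dichlorophenyl gave only a number 1.3 percentage points higher from compound 1 to compound 3 (within the scatter) and had made this ring look insensitive to its substituent. The same swap of chloro for hydrogen, made on an aromatic carbon elsewhere in the molecule, gives a number 6.7 percentage points higher from compound 2 to compound 4 (within the scatter) and so shows no clear change at that other place, which means that losing a chloro does not register the same way everywhere on these compounds.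

Nothing available explains why the number moves at this position.

Still open, from the compounds shown here alone, is whether the effect depends on the chloro that remains on the ring, and how a compound would read with a single chloro at the other position, or with a methyl group, an amine or a carboxylic acid on this ring in its place.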